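A few compounds are considered here, and "the series" means these few. Any claim that something is new, unique, unknown or untested is made for them only; others in the source may bear on it.

Compound 1 `CCCCNC(=O)c1cc(CCC)sc1N` was tested in an assay on isolated protein for inhibition of Polyunsaturated fatty acid lipoxygenase ALOX15 (Homo sapiens), read by spectrophotometry, with a stated time of 10 min; a lower number here means a stronger inhibitor, a higher number a weaker inhibitor. In this assay compound 1 gives >= 50000 nM, which is a limit of the measurement rather than a number. Compound 2 `CCCCNC(=O)c1cc(-c2ccc(Cl)cc2)sc1N` was tested in this assay as well. In this assay compound 2 gives >= 50000 nM, again a limit. The picture so far is therefore (the limit of >= 50000 nM in this assay, at which 2 of the 2 values shown sit), so compound 1 stands at the edge of what can be seen, with nothing weaker or stronger to compare against. Compound 3 `CCCCNC(=O)c1cc(Cc2ccccc2)sc1N` has not yet been measured. It differs from compound 1 by phenyl in place of ethyl on a saturated chain carbon bound to an aromatic carbon. For the measured compounds named here, no measured step between two compounds exists here to lean on. The step of a number no higher from compound 1 to compound 3 (the limit leaves the size open) is expected to be none beyond the scatter, since compound 1 sits at >= 50000 nM. Compound 3 is expected to give about 50000 nM in this assay, within a range from 20000 nM to 100000 nM.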

Compound 3, half-maximal inhibitory concentration: >= 50000 nM
Compound 3 was reported as a limit; the forecaster's own chance of this, stated with the estimate: 75%; the middle value sits exactly at the limit.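

For the compounds shown here, no step from compound 1 to compound 3 can be read, since both results are limits rather than numbers: the limit of >= 50000 nM in this assay, at which 3 of the 3 values shown sit. What these compounds leave open is how strongly any of them truly inhibits in this assay and whether phenyl in place of ethyl changes that at all.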